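A few compounds are considered here, and "the series" means these few. Any claim that something is new, unique, unknown or untested is made for them only; others in the source may bear on it.

Among the compounds with values here, compound 1 `O=c1cc(/C=C/C=C/c2ccc(O)c(O)c2)oc2ccccc12` gives 143000 nM in a physicochemical assay for inhibition, at 37 degrees C (on this read-out lower numbers stand for stronger inhibition and higher numbers for weaker inhibition), and stands as the highest of the two numbers measured so far; its nearest neighbour is compound 2 `O=c1cc(/C=C/C=C/c2ccc(O)c(O)c2)oc2cccc(O)c12`, which in this assay gives 125000 nM. Within the data shown here, the only step recorded is a 1.1-fold lower number from compound 1 to compound 2 (0.06 log units; within the scatter), a hydroxy in place of hydrogen on an aromatic carbon of the shared core.

Compound 3 `O=c1cc(/C=C/C=C/c2ccc(O)c(O)c2)oc2cc(O)ccc12` has not yet been measured. Relative to compound 1 the change is hydroxy in place of hydrogen on an aromatic carbon. Among the measured compounds shown here, the one step that bears on this is a 1.1-fold lower number from compound 1 to compound 2 (0.06 log units; within the scatter), since it too puts a hydroxy in place of hydrogen on an aromatic carbon of the same fused ring, although at a different place on that ring; that step stayed within the scatter. For the measured compounds named here, no second hydroxy-for-hydrogen step on this ring is available, so the influence of the place itself cannot be weighed from these data. The step of a 1.1-fold lower number from compound 1 to compound 3 (0.04 log units; within the scatter) is therefore expected to show no change beyond the scatter in either direction. Compound 3 is estimated at 130000 nM in this assay, with an expected range from 60000 nM to 280000 nM.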

Compound 3, half-maximal inhibitory concentration: 121000 nM
Compound 3: the middle estimate sits 1.1-fold (0.03 log units) above what was measured; the measured number falls inside the stated range.
By their numbers in this assay, from the lowest: compounds 3, 2 and 1 (each within the scatter of the next).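

In this assay there is a 1.2-fold lower number from compound 1 to compound 3 (0.07 log units; within the scatter) when a hydroxy enters meta to a fused ring and para to a fused ring, and that step stays within the scatter. Read with a 1.1-fold lower number from compound 1 to compound 2 (0.06 log units; within the scatter) this gives two places on the same six-membered aromatic ring where the hydroxy-for-hydrogen change produces no step beyond the scatter, which the single earlier step could not show. Nothing on hand offers an explanation for this result.

Still open, from the compounds shown here alone, is whether a group other than hydroxy at this place, such as methoxy, an amine or a carboxylic acid, would give a step beyond the scatter, and whether a hydroxy on the remaining aromatic carbons of this ring would behave as these two do. Also open, going by these compounds, is how much of the read-out depends on the parts that compounds 1, 2 and 3 all share, namely the two hydroxy groups outside this ring and the unsaturated chain joining them to the shared core, which a shorter or longer chain would begin to test.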